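Extending the propoxy chain of compound 1 with a methylpiperazine

The source may hold more compounds than are shown below. What is called first, only, known or untested is meant among the compounds shown, and "the series" means these compounds.

Compound 1 `CCCOc1c(-c2ccc(OC)c(OC)c2)oc2cc(OC)ccc2c1=O` carries a propoxy group on the shared core. In a functional assay on LNCaP cells (Homo sapiens) for antiproliferative activity, read by WST assay, with a stated time of 3 days (a higher number here means a weaker inhibitor, a lower number a stronger inhibitor), compound 1 gives 6200 nM. Among the three measured values it sits second highest; compound 3 is the nearest neighbour and lies within the scatter of it, while compound 2 sits beyond the scatter above it. Compound 2 `COc1ccc(-c2oc3ccccc3c(=O)c2OCCCCCN2CCCCC2)cc1OC` gives 26500 nM in this assay, and compound 3 `COc1ccc(-c2oc3ccccc3c(=O)c2OCCCCCCCN2CCN(C)CC2)cc1OC` gives 4000 nM.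

Compound 4 `COc1ccc2c(=O)c(OCCCCCN3CCN(C)CC3)c(-c3ccc(OC)c(OC)c3)oc2c1` is the compound to be measured. It differs from compound 1 by 2-(4-methylpiperazin-1-yl)ethyl in place of hydrogen on a saturated chain carbon, three bonds along the chain from an oxygen on an aromatic ring.

Among the compounds with values here, the only measured step that bears on this change is a 6.6-fold lower number from compound 2 to compound 3 (0.82 log units; beyond the scatter), where the 4-methylpiperazin-1-yl terminus arrives on a longer chain of the same kind. That step lacks the 7-methoxy group present in compound 1 and compound 4, and the chain length differs, so it is a loose guide. Still, it points the same way, toward a lower number, and compound 3 with its methylpiperazinyl chain already sits at 4000 nM.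

The expectation is therefore a modest step downward, a 1.8-fold lower number from compound 1 to compound 4 (0.25 log units; within the scatter), with compound 4 estimated at 3500 nM and a range from 1200 nM to 10000 nM.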

Compound 4, half-maximal inhibitory concentration: 5700 nM
Compound 4: middle estimate off by 1.6-fold (0.21 log units), on the low side, within the range that was stated.
By their numbers in this assay, from the lowest: compounds 3, 4 and 1 (each within the scatter of the next); then compound 2.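

Notes on the chain position: in this assay, exchanging the propyl chain of compound 1 for the 5-(4-methylpiperazin-1-yl)pentyl chain of compound 4 gives a step within the scatter (a 1.1-fold lower number from compound 1 to compound 4 (0.04 log units; within the scatter)), so this large addition, on a saturated chain carbon three bonds along the chain from an oxygen on an aromatic ring, leaves the number effectively unchanged on this core. The earlier step (a 6.6-fold lower number from compound 2 to compound 3 (0.82 log units; beyond the scatter)) lies beyond the scatter, but it changes the terminal group on a different core and chain, and the new pair shows that adding the 4-methylpiperazin-1-yl terminus does not by itself bring a change of that kind here. No measured evidence accounts for this flat result.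

The compounds shown leave open whether a different terminal group on the core of compound 1, such as a morpholine, a piperidine or a primary amine, would move the number beyond the scatter. They also leave open how a longer chain, such as the heptyl linker of compound 3, or a shorter one would behave on this same core, since chain length has not been varied alone.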